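The source may report more compounds than this note shows. Statements on the series, on what has been measured and on what is new or still open speak of the compounds shown alone.

Compound 1 `COc1cc(/C=C\c2ccc3ccccc3n2)cc(OC)c1OC`: 316 nM
Compound 2 `COc1cc(/C=C/c2ccc3ccccc3n2)cc(OC)c1OC`: 398 nM
Compound 3 `COc1cc(/C=C\c2ccc3cccnc3c2)cc(OC)c1OC`: 158 nM

In a functional assay on HT-29 cells (Homo sapiens) for cytotoxicity (on this read-out lower numbers stand for stronger inhibition and higher numbers for weaker inhibition), compound 3 gives the lowest of the three numbers; the gap to compound 1 lies within the scatter, the gap to compound 2 beyond it. Compound 4 `COc1cc(/C=C/c2ccc3cccnc3c2)cc(OC)c1OC` is the geometric counterpart of compound 3: the two compounds have the same atoms and bonds and differ only in configuration as drawn: 1 of 1 stereo elements differ; a double bond is drawn Z in compound 3 and E in compound 4. Going by the values given here, one measured step bears on this change: a 1.3-fold higher number from compound 1 to compound 2 (0.10 log units; within the scatter), which rests on (the fact that compounds 1 and 2 differ only in the configuration as drawn), the same drawn switch from Z to E. That step did not leave the scatter, so no step beyond the scatter is expected here either, with at most a slight drift toward a higher number, which is the expected 1.3-fold higher number from compound 3 to compound 4 (0.10 log units; within the scatter). Compound 4 is therefore estimated at 200 nM, with a range from 100 nM to 400 nM.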

Compound 4, half-maximal inhibitory concentration: 1580 nM
Compound 4: the middle estimate sits 7.9-fold (0.90 log units) below what was measured, and the stated range ends below it.
By their numbers in this assay, from the lowest: compounds 3, 1 and 2 (each within the scatter of the next, the first and the last beyond it); then compound 4.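

In this assay, the switch from Z to E does not behave alike in the two pairs: a 10-fold higher number from compound 3 to compound 4 (1.00 log units; beyond the scatter), whereas a 1.3-fold higher number from compound 1 to compound 2 (0.10 log units; within the scatter). The double bond's drawn geometry therefore matters clearly on the core of compound 3, with the Z form giving the lower number, though not on the core of compound 1. The gap can be set on that geometry alone: the fact that compounds 3 and 4 differ only in the configuration as drawn

The compounds shown do not tell why the two cores answer so differently. They also leave open whether the switch keeps this size once a further group, such as an amine, is carried on the core of compound 3.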